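An oxirane in place of isobutyl on compound 1

This account rests on a few compounds, and the source may have more. Where it says the series, first, only, none or still open, it means among the compounds named here.

Measured so far in a functional assay on HCT-116 cells (Homo sapiens) for inhibition, read by sulforhodamine B assay, with a stated time of 48 h, tested at 50 uM; a higher number here means more inhibition of growth at the concentration tested, a lower number less inhibition of growth:
Compound 1 `COc1cc2c(cc1CCC(C)C)C(=O)C[C@@H](c1ccc(O)cc1)O2`: 77%
Compound 2 `COc1ccc([C@@H]2C/C(=N/OCc3cn(-c4ccc(C(=O)c5ccccc5)cc4)nn3)c3cc(CC=C(C)C)c(OC)cc3O2)cc1`: 52%
Compound 3 `COc1ccc([C@@H]2C/C(=N/OCc3cn(-c4ccc(C#N)cc4)nn3)c3cc(CC=C(C)C)c(OC)cc3O2)cc1`: 50%

In this assay compound 1 gives 77%, the highest of the three numbers. Compound 2 at 52% and compound 3 at 50% both lie beyond the scatter beneath compound 1.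

The next compound is compound 4 `COc1cc2c(cc1CC1OC1(C)C)C(=O)C[C@@H](c1ccc(O)cc1)O2`, which keeps the core of compound 1 and changes one group: 3,3-dimethyloxiran-2-yl in place of isobutyl on a saturated chain carbon bound to an aromatic carbon. In words, 3,3-dimethyloxiran-2-yl stands in place of isobutyl on a saturated chain carbon bound to an aromatic carbon, and this brings in a three-membered non-aromatic ring.

For the measured compounds named here, the one measured step, a number 2 percentage points lower from compound 2 to compound 3 (within the scatter), swaps benzoyl for cyano on an aromatic carbon and stays within the scatter. It concerns a different group in a different place, so it offers only weak guidance. Going by the values given here, no measured pair tests this chain change, so the expectation is loose.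

The expected change is a number 7 percentage points lower from compound 1 to compound 4 (within the scatter), which means no step beyond the scatter is expected. The estimate for compound 4 is 70%, with an expected range from 48% to 88%.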

Compound 4, percent growth inhibition at one concentration: 97%
Compound 4: middle estimate off by 27 percentage points, on the low side; the measured number lies above the stated range.
By their numbers in this assay, from the lowest: compounds 3 and 2 (each within the scatter of the next); then compound 1; then compound 4.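

In this assay, 3,3-dimethyloxiran-2-yl in place of isobutyl on a saturated chain carbon bound to an aromatic carbon gives a number 20 percentage points higher from compound 1 to compound 4 (beyond the scatter), so this place on the core of compound 1 is sensitive to the group it carries. For the compounds shown here, the only earlier step concerned a different group in a different place, which makes this the first reading of what a change on this chain can do. The change adds both a three-membered non-aromatic ring and a hydrogen-bond acceptor, and nothing available explains the rise or shows which of the two goes with it.

Going by these compounds, it remains open whether the intact three-membered ring is needed, or whether a 2,3-dihydroxy-3-methylbutyl group would serve as well. An aziridine in the same place would test whether the ring oxygen matters.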